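A few compounds are considered here, and "the series" means these few. Any claim that something is new, unique, unknown or untested is made for them only; others in the source may bear on it.

Within the data shown here, compound 1, with the structure `COc1ccc2c(=O)c(/C=C/C(=O)Nc3cc(C)ccc3C)coc2c1`, is the one compound of this pair for which a number is recorded: in a functional assay on Huh-7 cells (Homo sapiens) for inhibition, read by MTT assay, with a stated time of 48 h (on this read-out lower numbers stand for stronger inhibition and higher numbers for weaker inhibition), compound 1 gives a half-maximal inhibitory concentration of 11100 nM. Compound 2, with the structure `Cc1ccc(CNC(=O)/C=C/c2coc3cc(O)ccc3c2=O)cc1`, is recorded only as a limit of the assay, not as a number; in this assay compound 2 gives > 100000 nM. That limit is described as the limit of > 100000 nM in this assay, at which 1 of the 2 values shown sits. Compound 3, with the structure `COc1ccc2c(=O)c(/C=C/C(=O)Nc3ccc(C)cc3)coc2c1`, has not yet been measured. It differs from compound 1 in one place: 4-methylphenyl in place of 2,5-dimethylphenyl on an amide-type nitrogen. Among the measured compounds shown here, no measured step between these compounds is available, so the expected step from compound 1 to compound 3 in this assay is set at roughly none beyond the usual scatter, written as a 1.1-fold higher number from compound 1 to compound 3 (0.03 log units; within the scatter). On that basis, compound 3 is estimated to give about 12000 nM in this assay, with the expected range running from 4000 nM to 40000 nM.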

Compound 3, half-maximal inhibitory concentration: > 100000 nM
Compound 3 ended at the assay's limit (the forecaster's own chance of this, stated with the estimate: 10%); middle value at least 8.3-fold (0.92 log units) away from the limit.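

In this assay, the change to 4-methylphenyl on the amide-type nitrogen is not neutral, as it gives an at least 9.0-fold higher number from compound 1 to compound 3 (0.95 log units; beyond the scatter). Among these compounds, the earlier compounds offered no one-place step, so this is the first sign that activity here depends on the aryl group at this position, with 2,5-dimethylphenyl giving a number and 4-methylphenyl not. Going by these compounds, the true size of the step stays unknown, since the read-out for compound 3 is a limit of the assay and not a number: the limit of > 100000 nM in this assay, at which 2 of the 3 values shown sit.

The compounds shown leave open whether the difference follows the methyl groups themselves or the whole aryl group. They also leave open how this position would respond to a cyclohexyl group, a 4-aminophenyl group or a 4-carboxyphenyl group in place of 2,5-dimethylphenyl.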